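The compounds below may be only part of what the source reports. "The series", "measured", "known", "first", "only" and "open" are said of these compounds alone.

Measured compounds in an assay on HEK293 cells for positive allosteric modulation of metabotropic glutamate receptor 3 (Rattus norvegicus), read by thallium flux, with a stated time of 2.5 min; on this read-out lower numbers stand for an effect already at smaller amounts and higher numbers for an effect only at larger amounts of compound:
- compound 1 `Cc1c(OCCCCOc2ccc(C(=O)O)c(Cl)c2)ccc(C(=O)CC(C)C)c1O` gives 2050 nM
- compound 3 `Cc1c(OCCCCOc2ccc(C(=O)O)c(Cl)c2)ccc(C(=O)CC2CCCC2)c1O` gives 2250 nM
- compound 2 `CCC(=O)c1ccc(OCCCCOc2ccc(F)c(C(=O)O)c2)c(C)c1O` has "not determined" (no result reported) as its result, so no number is available for it

For the measured compounds named here, compound 1 and compound 3 are the only two with numbers, and they stand close together: the step of a 1.1-fold higher number from compound 1 to compound 3 (0.04 log units; within the scatter) is within the scatter, so neither can be called the more potent one. The compound still to be measured is compound 4 `Cc1c(OCCCCOc2ccc(C(=O)O)cc2F)ccc(C(=O)CC(C)C)c1O`, which differs from compound 1 at the other end of the molecule: 4-carboxy-2-fluorophenyl in place of 4-carboxy-3-chlorophenyl on an oxygen on a saturated carbon.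

Going by the values given here, no measured step touches this end of the structure. Among the compounds with values here, the single step that exists, from compound 1 to compound 3, changes the group on the saturated chain carbon bound to the carbonyl carbon and was within the scatter, so it says nothing about swapping 4-carboxy-3-chlorophenyl for 4-carboxy-2-fluorophenyl. With no guidance, the expectation for compound 4 is a number near that of compound 1, with a step of a 1.2-fold higher number from compound 1 to compound 4 (0.09 log units; within the scatter) that is not expected to go beyond the scatter in either direction, though the range must stay wide. The estimate for compound 4 in this assay is therefore 2500 nM, between 800 nM and 8000 nM.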

Compound 4, half-maximal effective concentration: 1420 nM
Compound 4: middle estimate off by 1.8-fold (0.25 log units), on the high side; the measured number falls inside the stated range.
By their numbers in this assay, from the lowest: compounds 4, 1 and 3 (each within the scatter of the next).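

For the compounds shown here, this is the first measured change at this end of the molecule: in this assay, 4-carboxy-2-fluorophenyl in place of 4-carboxy-3-chlorophenyl gives a 1.4-fold lower number from compound 1 to compound 4 (0.16 log units; within the scatter) and so no real difference can be claimed. The swap exchanges chlorine for fluorine and, as the two group names show, also changes where the halogen sits on the ring, yet the number stays within the usual scatter. So, for this pair, the group on an oxygen on a saturated carbon can take this change with no clear shift in the read-out, and no evidence on the reason is available here.

Still open, going by these compounds, is how a ring carrying only the carboxylic acid, with no halogen at all, would read, and whether a tetrazole could take the place of that acid. Also open, on these data alone, is whether 4-carboxy-2-fluorophenyl would give a similar number alongside the cyclopentyl group of compound 3.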